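The compounds below may be only part of what the source reports. "The series", "measured", "known", "first", "only" and "open" are said of these compounds alone.

Measured in a functional assay on HBL-100 cells (Homo sapiens) for antiproliferative activity, read by sulforhodamine B assay, with a stated time of 48 h; on this read-out lower numbers stand for stronger inhibition of growth and higher numbers for weaker inhibition of growth:
- compound 1 `CCCCC(C#CC(=O)OC)O/C=C/C(=O)OC`: 250 nM
- compound 2 `CCCCCC(C#CC(=O)OC)O/C=C/C(=O)OC`: 1900 nM
- compound 3 `CC1CCC(C(C)C)C(OC(=O)C#CC(O/C=C/C(=O)OC2CC(C)CCC2C(C)C)C(C)C)C1`: > 100000 nM (a limit of the assay, not a number)

Of the two true numbers, compound 2 has the higher, 1900 nM. The third result, for compound 3, is only a limit.

Compound 4 `CCC(C#CC(=O)OC)O/C=C/C(=O)OC` differs from compound 2 by hydrogen in place of propyl on a saturated chain carbon, three bonds along the chain from an oxygen on an unsaturated carbon and a triple-bonded carbon. The same difference reads pentyl to ethyl.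

For the measured compounds named here, one measured step bears on this change: a 7.6-fold higher number from compound 1 to compound 2 (0.88 log units; beyond the scatter). That step lengthened the chain and raised the number, and it was modest but beyond the scatter. Compound 4 shortens the chain, so a lower number than compound 2 is expected in this assay. With a single step as a guide, the size stays uncertain, and a change within the scatter cannot be excluded.

The estimated change is a 4.2-fold lower number from compound 2 to compound 4 (0.63 log units; beyond the scatter).

For compound 4 the expected value is 450 nM, with an estimated range of 90 nM to 2500 nM.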

Compound 4, concentration for 50% growth inhibition: 320 nM
Beside the measured number, compound 4's estimate is 1.4-fold (0.15 log units) above it; measured number inside the range.
By their numbers in this assay, from the lowest: compounds 1 and 4 (each within the scatter of the next); then compound 2. At a limit, above all of these: compound 3.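

Measured in this assay and read at this one position, cutting pentyl to ethyl gives a 5.9-fold lower number from compound 2 to compound 4 (0.77 log units; beyond the scatter) and thus a change beyond the scatter, in the opposite direction to the earlier lengthening step. The comparison of the two shorter chains gives a 1.3-fold higher number from compound 1 to compound 4 (0.11 log units; within the scatter) and stays within the scatter, so among these three compounds the number responds to the change to pentyl, while compound 1 and compound 4 cannot be told apart. Nothing measured here gives a reason for this behaviour at the chain.

Going by these compounds, whether the number stays level with methyl or hydrogen in place of the ethyl of compound 4 remains open, as does the result for a longer chain than pentyl. Also open, on these data alone, is how an amine or a carboxylic acid on this chain would read.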